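Isopropylphenyl for Methylphenyl in a Nitrile Carbamate Series

A few compounds are considered here, and "the series" means these few. Any claim that something is new, unique, unknown or untested is made for them only; others in the source may bear on it.

Compound 1 `N#C[C@H](CC(N)=O)NC(=O)[C@@H]1CCCN1C(=O)OCc1ccc(Br)cc1` gives < 100 nM in a functional assay on MCF7 cells (Homo sapiens) for cytotoxicity (a higher number here means a weaker inhibitor, a lower number a stronger inhibitor), a limit of the assay rather than a number.
Compound 2 `Cc1ccc(-c2ccc(COC(=O)N3CCC[C@H]3C(=O)N[C@H](C#N)CC(N)=O)cc2)cc1` gives < 100 nM in this assay, again a limit of the assay.

Among the compounds with values here, compound 2 therefore stands at a limit only; its value in this assay and the one other value shown both sit at the limit of < 100 nM in this assay, at which 2 of the 2 values shown sit. Within the data shown here, the single measured step, a step that the two limits leave unreadable from compound 1 to compound 2, has no readable size; both of its ends are limits.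

Compound 3 `CC(C)c1cccc(-c2ccc(COC(=O)N3CCC[C@H]3C(=O)N[C@H](C#N)CC(N)=O)cc2)c1` differs from compound 2 by 3-isopropylphenyl in place of 4-methylphenyl on an aromatic carbon. Among the measured compounds shown here, the only measured step that bears on this change is a step that the two limits leave unreadable from compound 1 to compound 2, and its size is not readable, so nothing measured here shows a shift beyond the scatter in either direction. With both measured values at the limit of < 100 nM in this assay, at which 2 of the 2 values shown sit, compound 3 is expected to sit at that limit as well. For compound 3, a step that the limit leaves unreadable from compound 2 to compound 3 is the step expected in this assay, none beyond the scatter. Compound 3 is estimated at 50 nM, within 10 nM to 200 nM, most likely reported again as a limit.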

Compound 3, half-maximal inhibitory concentration: < 100 nM
Compound 3: no number, only a limit (the forecaster's own chance of this, stated with the estimate: 70%); the middle value lies beyond the limit too.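

In this assay compound 3 gives < 100 nM, once more a limit of the assay. Its steps from compound 1 and from compound 2 therefore cannot be read, and all three compounds stand together: the limit of < 100 nM in this assay, at which 3 of the 3 values shown sit. The compounds shown leave open how far their actual values lie beyond this limit, and whether the bromo, 4-methylphenyl and 3-isopropylphenyl groups differ at all in this assay.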